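Nitro-to-amino exchange on two aryl-azole cores

The source may report more compounds than this note shows. Statements on the series, on what has been measured and on what is new or still open speak of the compounds shown alone.

Measured compounds:
Compound 1 `COc1cc(OC)n2cc(-c3ccc([N+](=O)[O-])cc3)nc2n1` gives > 100000 nM in a functional assay on HT-29 cells (Homo sapiens) for antiproliferative activity, read by MTT assay, with a stated time of 72 h; on this read-out lower numbers stand for stronger inhibition of growth and higher numbers for weaker inhibition of growth; this is a limit of the assay, not a number.
Compound 2 `COc1cc(OC)n2cc(-c3ccc(N)cc3)nc2n1` gives > 100000 nM in this assay; again a limit.
Compound 3 `Cc1ccc2nc(-c3ccc([N+](=O)[O-])cc3)cn2c1` gives > 100000 nM in this assay; again a limit.

The change from compound 1 to compound 2 is amino in place of nitro on an aromatic carbon. Its step that the two limits leave unreadable from compound 1 to compound 2 cannot be sized, because of the limit of > 100000 nM in this assay, at which 3 of the 3 values shown sit. Compound 3 carries a different core; the difference between the two cores is not broken down here.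

Compound 4 `Cc1ccc2nc(-c3ccc(N)cc3)cn2c1` is not yet measured. It differs from compound 3 by amino in place of nitro on an aromatic carbon, the same change as that from compound 1 to compound 2. For compound 4 the step that the limit leaves unreadable from compound 3 to compound 4 is expected to be unreadable as well, resting on compound 3 at > 100000 nM and on the unreadable step from compound 1 to compound 2. Compound 4 is estimated at 150000 nM, with a range from 30000 nM to 1000000 nM, most likely reported as a limit.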

Compound 4, concentration for 50% growth inhibition: 82900 nM
Compound 4: middle estimate off by 1.8-fold (0.26 log units), on the high side; the range from low to high includes it.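

In this assay, the nitro-to-amino exchange on the core of compound 3 gives an at least 1.2-fold lower number from compound 3 to compound 4 (0.08 log units; that floor lies within the scatter), so this is a floor for the step and shows no change beyond the scatter. Compound 3 gives > 100000 nM, which is a limit of the assay. The true size of this step stays unknown, and neither its size nor its direction can be compared with the same exchange on the core of compound 1, as the step from compound 1 to compound 2 cannot be read: the limit of > 100000 nM in this assay, at which 3 of the 4 values shown sit.

Still open, going by these compounds, is how either core responds when a group such as a carboxylic acid or an acetamide stands in place of the amino. Also open, on these data alone, is whether any such group gives a value clear of the limit on both cores.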